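The source may hold more compounds than are shown below. What is called first, only, known or untested is meant among the compounds shown, and "the series" means these compounds.

Measured so far in a physicochemical assay for solubility, with a stated time of 24 h, tested at 30 mg/mL (a higher number here means a more soluble compound, a lower number a less soluble compound), for this series:
- compound 1 `O=C(CCCCCNc1c(NC2CCCCC2)c(=O)c1=O)NO` gives 8700000 nM
- compound 2 `Cc1cccc(Nc2c(NCCCCCC(=O)NO)c(=O)c2=O)c1` gives 11000000 nM

Compound 2 can be read only against compound 1. The gap between them (a 1.3-fold higher number from compound 1 to compound 2 (0.10 log units; within the scatter)) gives no ranking, so compound 2 stands level with compound 1 on these numbers.

Compound 3 `Cc1ccc(Nc2c(NCCCCCC(=O)NO)c(=O)c2=O)cc1` is not yet measured. It differs from compound 2 at one place (4-methylphenyl in place of 3-methylphenyl on a nitrogen on an aromatic ring), with 4-methylphenyl in place of 3-methylphenyl on a nitrogen on an aromatic ring, so the two have the same atoms joined differently.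

For the measured compounds named here, only one measured step bears on this change (a 1.3-fold higher number from compound 1 to compound 2 (0.10 log units; within the scatter)). It put 3-methylphenyl in place of cyclohexyl at that same place and stayed within the scatter. Going by the values given here, no measured compound carries 4-methylphenyl, so there is no direct precedent.

No step beyond the scatter is expected in this assay and neither direction is favoured. The expected step (a 1.1-fold lower number from compound 2 to compound 3 (0.04 log units; within the scatter)) is therefore small. For compound 3 the estimated value is 10000000 nM with an expected range from 6000000 nM to 17000000 nM on measurement.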

Compound 3, solubility: 1800000 nM
Compound 3: middle estimate off by 5.6-fold (0.74 log units), on the high side; the whole stated range lies above it.
By their numbers in this assay, from the lowest: compound 3; then compounds 1 and 2 (each within the scatter of the next).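

In this assay, this position on the nitrogen responds to a change that leaves the atoms the same: going from 3-methylphenyl to 4-methylphenyl gives a 6.1-fold lower number from compound 2 to compound 3 (0.79 log units; beyond the scatter), whereas 3-methylphenyl in place of cyclohexyl gave only a 1.3-fold higher number from compound 1 to compound 2 (0.10 log units; within the scatter). The comparison with the cyclohexyl compound gives a 4.8-fold lower number from compound 1 to compound 3 (0.68 log units; beyond the scatter), so compound 3 stands apart from both earlier compounds, and an aromatic ring at this place does not by itself go with the lower number, as compound 2 carries one and stands level with compound 1. Nothing at hand accounts for the difference between the 3-methylphenyl and 4-methylphenyl compounds.

As far as these compounds go, it remains open whether the lower number belongs to 4-methylphenyl specifically or extends to other groups at the same nitrogen, such as phenyl with no methyl, 4-chlorophenyl or 4-methoxyphenyl. From the compounds shown here alone, it is also open whether the gap between compound 2 and compound 3 persists with a longer chain on the other nitrogen, or with a carboxylic acid at the end of that chain.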